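From cyclopropyl to cyclopentyl: compound 2 to compound 4

The source may hold more compounds than are shown below. What is called first, only, known or untested is meant among the compounds shown, and "the series" means these compounds.

Measured in an ADME assay on liver (Homo sapiens) for metabolic stability, read by LC-MS, using microsomes and NADPH; on this read-out higher numbers stand for a more stable compound and lower numbers for a less stable compound:
Compound 1 `CCN(Cc1ccc(OCCN2C(=O)CCC2=O)c(C)c1)C(CC(=O)O)c1ccc(Cl)cc1`: 100%
Compound 2 `Cc1cc(CN(CC2CC2)C(CC(=O)O)c2ccc(Cl)cc2)ccc1OCCN1C(=O)CCC1=O`: 96%
Compound 3 `Cc1cc(CN(CC2CC2)[C@@H](CC(=O)O)c2ccc(Cl)cc2)ccc1OCCN1C(=O)CCC1=O`: 90%

In this assay compound 2 gives 96%, and the values on either side of it, for compound 1 and compound 3, lie within the scatter of it. Compound 4 `Cc1cc(CN(CC2CCCC2)C(CC(=O)O)c2ccc(Cl)cc2)ccc1OCCN1C(=O)CCC1=O` is not yet measured. It departs from compound 2 by cyclopentyl in place of cyclopropyl on a saturated chain carbon bound to an amine nitrogen, with cyclopentyl in place of cyclopropyl on a saturated chain carbon bound to an amine nitrogen. The closest guide is a number 4 percentage points lower from compound 1 to compound 2 (within the scatter), a change at the same place that stayed within the scatter. The other measured step, a number 6 percentage points lower from compound 2 to compound 3 (within the scatter), concerns only a stereocentre and does not bear on this change. An estimated step of a number 8 percentage points lower from compound 2 to compound 4 (within the scatter) is therefore expected, no larger than the scatter. For compound 4 the expected value is 88%, with an estimated range from 68% to 100%.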

Compound 4, percent of the compound remaining: 65%
The estimate for compound 4 lay 23 percentage points above the measured number, and the stated range ends above it.
By their numbers in this assay, from the lowest: compound 4; then compounds 3, 2 and 1 (each within the scatter of the next).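

The group on a saturated chain carbon bound to an amine nitrogen does matter in this assay, since cyclopentyl in place of cyclopropyl gives a number 31 percentage points lower from compound 2 to compound 4 (beyond the scatter), and cyclopentyl in place of methyl gives a number 35 percentage points lower from compound 1 to compound 4 (beyond the scatter). Methyl and cyclopropyl had stayed within the scatter of each other, so the earlier compounds gave no sign of this sensitivity. Nothing shown here accounts for the drop. Still open, as far as these compounds go, is where between cyclopropyl and cyclopentyl the loss sets in, as with cyclobutyl, and whether a tetrahydropyranyl ring or a longer chain would keep the number high.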